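Swapping a fluorophenyl for a bicyclic heteroaryl on the sulfonyl

A few compounds are considered here, and "the series" means these few. Any claim that something is new, unique, unknown or untested is made for them only; others in the source may bear on it.

Measured compounds:
compound 1 `CN1CC=C(c2cn(S(=O)(=O)c3cccc(Cl)c3)c3ccccc23)CC1`, 1 nM
compound 2 `CC(C)(C)OC(=O)N1CC=C(c2cn(S(=O)(=O)c3ccccc3)c3ccccc23)CC1`, 54 nM
compound 3 `O=S(=O)(c1ccccc1F)n1cc(C2=CCNCC2)c2ccccc21`, 1 nM

All three compounds share one core, an indole carrying a sulfonyl-linked aryl group and a tetrahydropyridine. In an assay on HeLa cells for binding affinity to 5-hydroxytryptamine receptor 6 (Homo sapiens) (a higher number here means a weaker inhibitor, a lower number a stronger inhibitor), compound 3 gives 1 nM, level with compound 1 at the digits shown, which in this assay gives 1 nM; the two are within the usual scatter of each other. Compound 2, which in this assay gives 54 nM, stands well apart with a much higher number.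

Compound 4 `O=S(=O)(c1nccc2sncc12)n1cc(C2=CCNCC2)c2ccccc21` has not yet been measured. It differs from compound 3 in one place: a group of 9 heavy atoms (6 carbon, 2 nitrogen, 1 sulfur; one five-membered aromatic ring with 2 hetero atoms, one six-membered aromatic ring with 1 hetero atom) in place of a group of 7 heavy atoms (6 carbon, 1 fluorine; one six-membered aromatic ring of carbon only), on a sulfonyl sulfur. Among the compounds with values here, no measured pair shows this kind of change, so the size of the step is uncertain. Since compound 3 already sits at a very low number, a modest rise is expected, close to the edge of the scatter; compound 4 is estimated at 3 nM, within a range from 0.5 nM to 20 nM, meaning a step of a 3.0-fold higher number from compound 3 to compound 4 (0.48 log units; beyond the scatter).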

Compound 4, inhibition constant: 5 nM
Compound 4: the middle estimate sits 1.7-fold (0.22 log units) below what was measured; the measured number falls inside the stated range.
By their numbers in this assay, from the lowest: compounds 1 and 3 (each within the scatter of the next); then compound 4; then compound 2.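

In this assay, the step from the 2-fluorophenyl group to a larger group with two aromatic rings, one five-membered and one six-membered, on the sulfonyl sulfur gives a 5.0-fold higher number from compound 3 to compound 4 (0.70 log units; beyond the scatter). Within the data shown here, this is the first direct reading at this position, and it shows that the position accepts this much larger group with only a modest rise, as compound 4 still gives 5 nM. Nothing available explains why the number rises.

Among these compounds, the single swap changes the ring count, the hetero atoms and the fluorine all at once, so their separate contributions stay unknown. On these data alone, a pyridyl or naphthyl group on the sulfonyl sulfur would help separate them, and whether either would sit closer to compound 3 or to compound 4 remains open.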